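Amide variation on the chromone series: carbamate in place of aryl

The source may report more compounds than this note shows. Statements on the series, on what has been measured and on what is new or still open speak of the compounds shown alone.

Within the data shown here, compound 1 `Cc1ccc(C(=O)Nc2ccc(O)c3c(=O)cc(-c4ccccc4Cl)oc23)cc1` is the only member of the series with a number: in a functional assay on ID8 cells (Mus musculus) for antiproliferative activity (on this read-out lower numbers stand for stronger inhibition and higher numbers for weaker inhibition), compound 1 gives 16000 nM. Compound 2 `Cc1ccc(C(=O)Nc2c(O)cc(O)c3c(=O)cc(-c4ccccc4Cl)oc23)cc1` has no reported result in this assay: for compound 2 the entry reads "not determined" (no result reported). Compound 3 `C[C@H](NC(=O)OC(C)(C)C)C(=O)Nc1ccc(O)c2c(=O)cc(-c3ccccc3Cl)oc12` differs from compound 1 in one place: 1-((tert-butoxycarbonyl)amino)ethyl in place of 4-methylphenyl on a carbonyl carbon. Among the measured compounds shown here, no measured pair shows the effect of such a change, so the size of the step is open; a step from compound 1 to compound 3 near or somewhat beyond the scatter, towards weaker inhibition, is expected a 1.4-fold higher number from compound 1 to compound 3 (0.14 log units; within the scatter). Compound 3 is therefore estimated at 22000 nM, within 6000 nM to 80000 nM.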

Compound 3, half-maximal inhibitory concentration: 9800 nM
Beside the measured number, compound 3's estimate is 2.2-fold (0.35 log units) above it; the measured number falls inside the stated range.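

In this assay, 1-((tert-butoxycarbonyl)amino)ethyl in place of 4-methylphenyl on the carbonyl carbon gives a 1.6-fold lower number from compound 1 to compound 3 (0.21 log units; within the scatter). At this position, then, an acyl group without a ring and with one defined stereocentre reads the same as the aromatic one, so the aromatic ring is not needed to keep the read-out at this level. Nothing available explains this result.

Still open, from the compounds shown here alone, is whether a free amine in place of the carbamate, or a carboxylic acid, would move the number beyond the scatter. The opposite stereocentre is equally unresolved.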